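The source may hold more compounds than are shown below. What is called first, only, known or untested is meant among the compounds shown, and "the series" means these compounds.

Compound 1 `COc1ccc(Nc2nc3ccccc3cc2-c2ccc(C)cc2)cc1`: 118000 nM
Compound 2 `Cc1ccc(-c2ccnc(Nc3ccc(F)cc3)c2)cc1`: 146000 nM
Compound 3 `Fc1ccc(Nc2ccc3ccccc3n2)cc1`: 65000 nM

Of the compounds shown here, three have been measured in an ADME assay on PBMC cells (Homo sapiens) for cytotoxicity, read by MTT assay, with a stated time of 72 h, in the presence of a further agent that is not named here; on this read-out higher numbers stand for weaker inhibition and lower numbers for stronger inhibition. Compound 1 gives 118000 nM, compound 2 gives 146000 nM, and compound 3 gives 65000 nM. Of these three numbers compound 2 has the highest. Compound 1 sits within the scatter of compound 2, so the two cannot be told apart on this read-out, while compound 3 sits beyond the scatter, below compound 2.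

Compound 4 `COc1ccc(Nc2cc(-c3ccc(C)cc3)ccn2)cc1` has not yet been measured. It differs from compound 2 in one place: methoxy in place of fluoro on an aromatic carbon. The methoxy enters on an aromatic carbon of a six-membered aromatic ring of carbon only, para to a large group, where the fluoro leaves.

Among the measured compounds shown here, no measured pair differs in exactly this way, so there is no direct precedent for the size of the step. Compound 1, which also carries a methoxy group, gives 118000 nM, a number within the scatter of compound 2. On that basis the step is expected to be small, with no clear direction beyond the scatter, as a 1.2-fold lower number from compound 2 to compound 4 (0.07 log units; within the scatter). Compound 4 is therefore expected to give about 125000 nM, with a range from 60000 nM to 260000 nM.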

Compound 4, half-maximal inhibitory concentration: 34000 nM
Compound 4: middle estimate off by 3.7-fold (0.57 log units), on the high side, and the stated range ends above it.
By their numbers in this assay, from the lowest: compounds 4, 3, 1 and 2 (each within the scatter of the next, the first and the last beyond it).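

In this assay, among the compounds shown here, methoxy in place of fluoro, on an aromatic carbon of a six-membered aromatic ring of carbon only, para to a large group, gives a 4.3-fold lower number from compound 2 to compound 4 (0.63 log units; beyond the scatter) and so provides the first single-place change that can be read in this set, a modest one that lies beyond the scatter. The position therefore responds to the group it carries: exchanging fluoro for methoxy, which brings two heavy atoms for one and one hydrogen-bond acceptor where none was counted, moves the number towards stronger inhibition. Nothing available bears on why the number moves, and a single pair cannot separate the contribution of the oxygen from that of the added carbon.

Whether the step follows the oxygen or the carbon stays open, since neither a hydroxyl nor a methyl group at this position is among the compounds shown. Also open, on these data alone, is how a larger ethoxy group, a morpholine or a carboxylic acid would read here, and whether the same exchange on the core of compound 3 would move the number in the same direction.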